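The source may report more compounds than this note shows. Statements on the series, on what has been measured and on what is new or still open speak of the compounds shown alone.

Of the compounds shown here, three built on one shared core have been measured in an assay for inhibition of Fatty-acid amide hydrolase 1 (Rattus norvegicus); a higher number here means a weaker inhibitor, a lower number a stronger inhibitor. Compound 1 `CS(=O)(=O)c1cnc(C(=O)CCc2ccc(-c3ccccc3)cc2)o1` gives 1.2 nM. Compound 2 `COC(=O)c1cnc(C(=O)CCc2ccc(Oc3ccccc3)cc2)o1` gives 1.7 nM. Compound 3 `CSc1cnc(C(=O)CCc2ccc(-c3ccccc3)cc2)o1` gives 3 nM. Among these, compound 3 has the highest number of the three; its gap to compound 2 lies within the usual scatter, while its gap to compound 1 lies beyond it, as the step of a 2.5-fold higher number from compound 1 to compound 3 (0.40 log units; beyond the scatter) shows, a modest change that came from swapping one small group at the same ring position.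

Compound 4 `COC(=O)c1cnc(C(=O)CCc2ccc(-c3ccccc3)cc2)o1` has not yet been measured. It differs from compound 3 in one place: methoxycarbonyl in place of methylsulfanyl on an aromatic carbon. Among the measured compounds shown here, the only measured step that touches this position is a 2.5-fold higher number from compound 1 to compound 3 (0.40 log units; beyond the scatter), and it was modest in size. For the measured compounds named here, compound 2 carries the same methoxycarbonyl group as compound 4 but a different tail; no single-change step links those two, so only their two values can be compared, and the value of compound 2 sits close to that of compound 1.

Compound 4 is therefore expected to move a little downward from compound 3, a step of a 2.0-fold lower number from compound 3 to compound 4 (0.30 log units; within the scatter), and is estimated at 1.5 nM with a range from 0.6 nM to 4 nM.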

Compound 4, inhibition constant: 1.5 nM
For compound 4 middle estimate and measured number coincide at the digits printed; the measured number falls inside the stated range.
By their numbers in this assay, from the lowest: compounds 1, 4, 2 and 3 (each within the scatter of the next, the first and the last beyond it).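

Compound 4 adds a third group at this position, on the aromatic carbon next to the ring oxygen, with the phenyl tail held constant in this assay. Placing methoxycarbonyl there in place of methylsulfanyl gives a 2.0-fold lower number from compound 3 to compound 4 (0.30 log units; within the scatter), and placing it there in place of methylsulfonyl gives a 1.3-fold higher number from compound 1 to compound 4 (0.10 log units; within the scatter), so compound 4 cannot be told apart from either neighbour, even though the direct swap between those two groups gives a 2.5-fold higher number from compound 1 to compound 3 (0.40 log units; beyond the scatter). Among the compounds shown here, compound 4 also provides the first single-change reading at the far end of the tail, where phenyl in place of phenoxy, with methoxycarbonyl held constant, gives a 1.1-fold lower number from compound 2 to compound 4 (0.05 log units; within the scatter), so this swap makes no difference that can be read beyond the scatter.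

The data shown offer no independent measurement that explains why these compounds lie so close together. On these data alone, it remains open whether an amine, a carboxylic acid or a longer chain at this ring carbon would also stay this close, and whether phenoxy and phenyl would still match with methylsulfonyl or methylsulfanyl at this position.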